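The compounds below may be only part of what the source reports. "The series", "measured", "known", "first", "only" and "open" are said of these compounds alone.

Measured in a functional assay on HepG2 cells (Homo sapiens) for inhibition, read by MTT assay, with a stated time of 48 h; on this read-out lower numbers stand for stronger inhibition and higher numbers for weaker inhibition:
- Compound 1 `COc1ccc(-n2c(SC)nnc2-c2cc(OC)c(OC)c(OC)c2)cc1`: > 60000 nM (a limit)
- Compound 2 `CCSc1nnc(-c2cc(OC)c(OC)c(OC)c2)n1-c1ccc(OC)cc1`: > 60000 nM (a limit)
- Compound 3 `COc1ccc(-n2c(SCC(=O)c3ccc(F)cc3)nnc2-c2cc(OC)c(OC)c(OC)c2)cc1`: 10700 nM

Among the measured compounds shown here, compound 3 is the only one with a true number, 10700 nM. Compound 1 and compound 2 rest on (the limit of > 60000 nM in this assay, at which 2 of the 3 values shown sit).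

Compound 4 `COc1ccc(-n2c(SCC(=O)Nc3ccc(Cl)cc3)nnc2-c2cc(OC)c(OC)c(OC)c2)cc1` carries (4-chlorophenyl)amino in place of 4-fluorophenyl on a carbonyl carbon.

For the measured compounds named here, two measured steps bear on this: an at least 5.6-fold lower number from compound 1 to compound 3 (0.74 log units; beyond the scatter), and an at least 5.6-fold lower number from compound 2 to compound 3 (0.74 log units; beyond the scatter). Both came with adding the (4-fluorophenyl)carbonyl, and compound 4 keeps a carbonyl and a carbon-only aromatic ring there. Going by the values given here, no measured step covers the swap itself, so no change beyond the scatter is expected in this assay. The expected step is a 1.1-fold higher number from compound 3 to compound 4 (0.05 log units; within the scatter). The estimate for compound 4 is 12000 nM, with an expected range of 4000 nM to 40000 nM.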

Compound 4, half-maximal inhibitory concentration: > 60000 nM
Compound 4: only a limit was reported; the forecaster's own chance of this, stated with the estimate: 20%; at least 5.0-fold (0.69 log units) between middle value and limit.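

In this assay, keeping a carbonyl on the chain is not enough: (4-chlorophenyl)amino in place of 4-fluorophenyl on that carbonyl carbon gives an at least 5.6-fold higher number from compound 3 to compound 4 (0.74 log units; beyond the scatter). The gain seen with (4-fluorophenyl)carbonyl therefore depends on what the carbonyl carbon carries, not on the carbonyl alone. The steps to compound 4 from compound 1 and compound 2 cannot be read, and compound 4 gives only a limit: the limit of > 60000 nM in this assay, at which 3 of the 4 values shown sit.

This change brings in both the amino link and chlorine in place of fluorine, so the compounds shown cannot separate the two. Neither (4-fluorophenyl)amino nor 4-chlorophenyl on that carbonyl carbon appears among them.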